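The compounds below may be only part of what the source reports. "The series", "measured", "known", "first", "only" and "open" are said of these compounds alone.

Measured in a functional assay on THP-1 cells (Homo sapiens) for inhibition; on this read-out higher numbers stand for weaker inhibition of growth and lower numbers for stronger inhibition of growth:
- compound 1 `Cc1noc(C)c1-c1ccc2c(c1)c(CCc1ccccc1)cn2CCCCCCC(=O)NO`: 15500 nM
- compound 2 `Cc1ccccc1Cc1cn(CCCCCC(=O)NO)c2ccc(-c3c(C)noc3C)cc12`: 15500 nM

In this assay, compound 1 at 15500 nM stands level with compound 2 at 15500 nM, the two showing no difference at the digits given. Compound 3 `Cc1cccc(Cc2cn(CCCCCCC(=O)NO)c3ccc(-c4c(C)noc4C)cc23)c1` has not yet been measured. It has the same atoms as compound 1, joined differently: 3-methylphenyl in place of benzyl on a saturated chain carbon bound to an aromatic carbon. In words, 3-methylphenyl stands in place of benzyl on a saturated chain carbon bound to an aromatic carbon, which can also be read as phenethyl to 3-methylbenzyl. Within the data shown here, no measured step shows what such a change does in this assay, so no direction is favoured and no shift beyond the scatter is expected. The expected step is a 1.1-fold lower number from compound 1 to compound 3 (0.04 log units; within the scatter). For compound 3 the estimated value is 14000 nM, with an expected range from 6000 nM to 30000 nM.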

Compound 3, concentration for 50% growth inhibition: 15500 nM
Estimate against measurement, compound 3: 1.1-fold (0.04 log units) below, within the range that was stated.
By their numbers in this assay, from the lowest: compounds 1, 2 and 3 (each within the scatter of the next).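

In this assay, among these compounds, the earlier compounds offered no step at this position, and the move from phenethyl to 3-methylbenzyl now supplies the first one, with no change at the digits printed from compound 1 to compound 3 (within the scatter). Read the other way, this is 3-methylphenyl in place of benzyl on a saturated chain carbon bound to an aromatic carbon, so this one rearrangement of the same atoms leaves the read-out where it stood on the core of compound 1. Nothing available bears on why this is so.

The compounds shown leave open whether a group of another kind at this place, such as an amine or a carboxylic acid, would give a different number in this assay. They also leave open what a longer chain in place of phenethyl would give there.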